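Methylsulfonyl in place of acetyl in the series

The compounds below may be only part of what the source reports. "The series", "measured", "known", "first", "only" and "open" are said of these compounds alone.

In an ADME assay on microsomes from liver (Mus musculus) for metabolic stability, with a stated time of 10 min (a higher number here means that more of the compound is left, a lower number that less of the compound is left), compound 1 (`COc1ccc(CNC(=O)N2C[C@@H](c3ccc(C(O)(C(F)(F)F)C(F)(F)F)cc3)[C@@](C)(c3ccc(F)cc3)C2)cc1`) gives 67% and compound 2 (`C[C@]1(c2ccc(F)cc2)CN(C(=O)NCc2ccc(C#N)cc2)C[C@H]1c1ccc(C(O)(C(F)(F)F)C(F)(F)F)cc1`) gives 51% while compound 3 (`CC(=O)N1CCC(C(=O)N2C[C@@H](c3ccc(C(O)(C(F)(F)F)C(F)(F)F)cc3)[C@@](C)(c3ccc(F)cc3)C2)CC1`) stands highest of the three at 81% in this set. Compound 4 (`C[C@]1(c2ccc(F)cc2)CN(C(=O)C2CCN(S(C)(=O)=O)CC2)C[C@H]1c1ccc(C(O)(C(F)(F)F)C(F)(F)F)cc1`) carries methylsulfonyl in place of acetyl on an amine nitrogen in a ring. Among the measured compounds shown here, no measured step touches this group directly. The nearest steps are modest: a number 14 percentage points higher from compound 1 to compound 3 (beyond the scatter) and a number 30 percentage points higher from compound 2 to compound 3 (beyond the scatter) replace the whole group on the carbonyl carbon, and a number 16 percentage points lower from compound 1 to compound 2 (beyond the scatter) comes from cyano in place of methoxy. The rest of compound 3 stays unchanged here, so no step beyond the scatter is expected. The expected change is a number 4 percentage points lower from compound 3 to compound 4 (within the scatter) in this assay on this estimate. For compound 4 the estimated value is 77% with an expected range from 62% to 90% in this read-out.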

Compound 4, percent of the compound remaining: 80%
Beside the measured number, compound 4's estimate is 3 percentage points below it; the measured number falls inside the stated range.
By their numbers in this assay, from the lowest: compound 2; then compound 1; then compounds 4 and 3 (each within the scatter of the next).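

In this assay, among the compounds shown here, methylsulfonyl replaces acetyl on the amine nitrogen in a ring with a number 1 percentage points lower from compound 3 to compound 4 (within the scatter) and this is the first measured step at this group itself. The 1-(methylsulfonyl)piperidin-4-yl group on the carbonyl carbon also stands clear of both benzylamino groups, with a number 29 percentage points higher from compound 2 to compound 4 (beyond the scatter) and with a number 13 percentage points higher from compound 1 to compound 4 (beyond the scatter) so the earlier separation from these two compounds is not confined to the 1-acetylpiperidin-4-yl group. No measured evidence accounts for these numbers.

Still open, from the compounds shown here alone, is how ethylsulfonyl or a longer chain on this nitrogen would read in this assay.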